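A few compounds are considered here, and "the series" means these few. Any claim that something is new, unique, unknown or untested is made for them only; others in the source may bear on it.

compound 1 `Cc1nccn1-c1cnc(NCc2c(F)ccc3c2CCO3)c2cn[nH]c(=O)c12`: 2.1
compound 2 `O=C1CCCN1c1cnc(NCc2c(F)ccc3c2CCO3)c2cn[nH]c(=O)c12`: 1.8
compound 3 `Cc1ncc(-c2cnc(NCc3c(F)ccc4c3CCO4)c3cn[nH]c(=O)c23)n1C`: 1.9

These three values come from a physicochemical assay for lipophilicity, using the shake flask method, in phosphate buffer, measured as octanol-water partition, with a stated time of 30 min, at pH 7.4; a higher number here means a more lipophilic compound, a lower number a more polar compound. They differ only in one group on the shared core, and compound 3, at 1.9, lies within the scatter of both other compounds. Compound 4 `CN(C)C(=O)c1cc(-c2cnc(NCc3c(F)ccc4c3CCO4)c3cn[nH]c(=O)c23)n(C)n1` has not yet been measured. It differs from compound 3 by one exchange: 3-(dimethylcarbamoyl)-1-methyl-1H-pyrazol-5-yl in place of 1,2-dimethyl-1H-imidazol-5-yl on an aromatic carbon.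

For the measured compounds named here, three measured steps bear on this, all exchanges at that same place on the core: a number 0.20 log units lower from compound 1 to compound 3 (within the scatter), a number 0.10 log units higher from compound 2 to compound 3 (within the scatter) and a number 0.30 log units lower from compound 1 to compound 2 (within the scatter). None of them leaves the scatter, so the exchange in compound 4 gives no firm reason to expect a clear shift in this assay. Going by the values given here, still, no measured compound carries the 3-(dimethylcarbamoyl)-1-methyl-1H-pyrazol-5-yl group, so this expectation is uncertain.

The expected change is a number 0.10 log units higher from compound 3 to compound 4 (within the scatter), which would not stand out from the scatter.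

For compound 4 the estimated value is 2, with an expected range from 1.5 to 2.5.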

Compound 4, distribution coefficient: 2.1
Estimate against measurement, compound 4: 0.10 log units below; measured number inside the range.
By their numbers in this assay, from the lowest: compounds 2, 3, 1 and 4 (each within the scatter of the next).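

With the 3-(dimethylcarbamoyl)-1-methyl-1H-pyrazol-5-yl group on the aromatic carbon, this assay shows a number 0.20 log units higher from compound 3 to compound 4 (within the scatter) and a number 0.30 log units higher from compound 2 to compound 4 (within the scatter) and no change at the digits printed from compound 1 to compound 4 (within the scatter). For the compounds shown here, this position on the shared core has now carried four different groups, including one with a dimethylcarbamoyl substituent on its five-membered aromatic ring, and no step among the four compounds leaves the scatter. No measurement given here explains why the read-out stays so level across these exchanges.

Going by these compounds, it remains open whether a group bearing a basic amine or a carboxylic acid at this position would give a step beyond the scatter. The plain 1-methyl-1H-pyrazol-5-yl group, without its dimethylcarbamoyl substituent, would be needed to separate the contribution of the ring from that of the substituent.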